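Working notes: the step from compound 2 to compound 4

This account rests on a few compounds, and the source may have more. Where it says the series, first, only, none or still open, it means among the compounds named here.

Compound 1 `COc1cccc2c1CN(C(=O)c1cc(S(C)(=O)=O)ccc1O[C@@H](C)C(F)(F)F)C2` gives 85 ug/mL as its measured value
Compound 2 `CC(C)Oc1ccc(S(C)(=O)=O)cc1C(=O)N1Cc2ccc(C3CCOCC3)cc2C1` gives 191 ug/mL as its measured value
Compound 3 `CS(=O)(=O)c1ccc(OCCC(F)(F)F)c(C(=O)N2Cc3cc(C(F)(F)F)cnc3C2)c1` gives 513 ug/mL as its measured value

In a physicochemical assay for solubility (on this read-out higher numbers stand for higher solubility and lower numbers for lower solubility), compound 2 gives 191 ug/mL as the middle of the three numbers. Compound 1 at 85 ug/mL lies lower and compound 3 at 513 ug/mL lies higher, each gap beyond the usual scatter.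

Compound 4 `CS(=O)(=O)c1ccc(-c2ccc(F)cc2)c(C(=O)N2Cc3ccc(C4CCOCC4)cc3C2)c1` is not yet measured. It differs from compound 2 by 4-fluorophenyl in place of isopropoxy on an aromatic carbon in one place, with 4-fluorophenyl in place of isopropoxy on an aromatic carbon, ortho to a large group and para to a methylsulfonyl group.

Among the measured compounds shown here, no measured pair covers this change, and no measured compound carries 4-fluorophenyl, so the size of the step is a judgement. A fall beyond the scatter is expected in this assay rather than a flat result. The estimate takes compound 2 at 191 ug/mL as its starting number. The estimated change is a 7.6-fold lower number from compound 2 to compound 4 (0.88 log units; beyond the scatter) in the downward direction. For compound 4 the estimated value is 25 ug/mL within a range of 6 ug/mL to 90 ug/mL on this read-out.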

Compound 4, solubility: 15 ug/mL
Beside the measured number, compound 4's estimate is 1.7-fold (0.22 log units) above it; the measured number falls inside the stated range.
By their numbers in this assay, from the lowest: compound 4; then compound 1; then compound 2; then compound 3.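

In this assay, the aromatic carbon para to a methylsulfonyl group responds strongly to what it carries: 4-fluorophenyl in place of isopropoxy gives a 13-fold lower number from compound 2 to compound 4 (1.10 log units; beyond the scatter), a large step. Among the compounds shown here, the earlier compounds differ from each other in more than one place, so their numbers could not tie any change to this carbon alone; this is the first step that can be read at a single place, and it swaps a ringless group with a hydrogen-bond acceptor for an aromatic ring with none. No measurement available here explains the size of this step.

The compounds shown leave open whether the fall follows the aromatic ring itself or its fluorine, since phenyl without fluorine does not appear among them. From the compounds shown here alone, how an amine or a carboxylic acid would read at this carbon also remains open.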